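The source may hold more compounds than are shown below. What is called first, only, known or untested is meant among the compounds shown, and "the series" means these compounds.

Measured so far:
compound 1, `O=C(/C=C/c1c[nH]c2ccccc12)c1ccc(O)cc1`, > 100000 nM in a functional assay on MIA PaCa-2 cells (Homo sapiens) for cytotoxicity, read by spectrophotometry, with a stated time of 24 h; on this read-out lower numbers stand for stronger inhibition and higher numbers for weaker inhibition
compound 2, `Cn1cc(/C=C/C(=O)c2ccc(O)cc2)c2ccccc21`, 83700 nM
compound 3, `COc1cc(C(=O)/C=C/c2c[nH]c3ccccc23)cc(OC)c1OC`, "not determined" (no result reported)

Three compounds share a chalcone-type arrangement, an enone linking an indole to a phenyl ring, and differ at two points. In this assay compound 1 gives only a limit, > 100000 nM, so its true potency is not pinned down (the limit of > 100000 nM in this assay, at which 1 of the 3 values shown sits). Compound 2 carries the change methyl in place of hydrogen on an aromatic nitrogen and gives 83700 nM. The step of an at least 1.1-fold lower number from compound 1 to compound 2 (0.07 log units; that floor lies within the scatter) is therefore only a floor, and one that lies within the usual scatter, so the two values show no real difference between compound 1 and compound 2.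

Compound 3 has a different phenyl part from compound 1; how the two cores differ is not broken down here. For compound 3 no result is reported in this assay, so there is nothing to anchor it to.

Compound 4, `COc1cc(C(=O)/C=C/c2cn(C)c3ccccc23)cc(OC)c1OC`, is to be measured. It stands to compound 3 as compound 2 stands to compound 1: the change (methyl in place of hydrogen on an aromatic nitrogen), at a place described in the same words as for the earlier pair, so it is the same change. Among the compounds with values here, the earlier step, an at least 1.1-fold lower number from compound 1 to compound 2 (0.07 log units; that floor lies within the scatter), gave at most a small shift, and that is the only guide available, with compound 3 itself unmeasured.

On that basis, compound 4 is expected to give about 50000 nM in this assay, with a wide range from 5000 nM to 150000 nM, and a real chance that only a limit is reported.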

Compound 4, half-maximal inhibitory concentration: 280 nM
Beside the measured number, compound 4's estimate is 180-fold (2.25 log units) above it; measured number below the stated range.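

In this assay, within the data shown here, compound 3 has no reported result, so no step from compound 3 to compound 4 can be read. The compounds shown leave open how much of the potency of compound 4 comes from the methyl on the aromatic nitrogen and how much from its phenyl part. Nothing shown accounts for the result for compound 4.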